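The compounds below may be only part of what the source reports. "The series", "measured", "known", "first", "only" and "open" are said of these compounds alone.

Of the compounds shown here, three built on one shared core have been tested in a functional assay on the whole organism (strain Swiss) with Mus musculus as the target, in the maximal electroshock model, with a stated time of 0.5 h, at a dose of 300 mg/kg by the intraperitoneal route; a lower number here means a weaker effect, a higher number a stronger effect of the compound at the dose given. Compound 1 `COc1cccc(N2CCN(C(=O)C(C)N3C(=O)CCC3=O)CC2)c1` gives 50%. Compound 2 `CCC(C(=O)N1CCN(c2ccc(C(F)(F)F)cc2)CC1)N1C(=O)CCC1=O` gives 0%, and compound 3 `CCC(C(=O)N1CCN(c2ccccc2)CC1)N1C(=O)CCC1=O` gives 75%. On these numbers compound 1 stands second of the three: compound 3 lies above it by a margin beyond the scatter, and compound 2 lies below it by a larger margin, also beyond the scatter.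

Compound 4 `CC(C(=O)N1CCN(c2ccc(F)cc2)CC1)N1C(=O)CCC1=O` has not yet been measured. It differs from compound 1 in one place: 4-fluorophenyl in place of 3-methoxyphenyl on an amine nitrogen in a ring. For the measured compounds named here, only one measured step is a change on that aromatic ring, and it shows a number 75 percentage points higher from compound 2 to compound 3 (beyond the scatter). That step concerns a trifluoromethyl group rather than a fluorine atom, and its two compounds also differ from compound 1 and compound 4 elsewhere in the shared core, so it bears on the present step only loosely. Going by the values given here, no measured pair shows what exchanging a 3-methoxyphenyl for a 4-fluorophenyl does. The expectation is therefore a step of no change at the digits printed from compound 1 to compound 4 (within the scatter), that is, none beyond the scatter. Compound 4 is accordingly estimated at 50%, within an expected range from 25% to 75%.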

Compound 4, a percentage reported as activity, at one dose (the size of the read-out at that dose, not a potency): 50%
Compound 4: the middle estimate sits on the measured number at the digits printed, within the range that was stated.
By their numbers in this assay, from the lowest: compound 2; then compounds 1 and 4 (each within the scatter of the next); then compound 3.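

In this assay the exchange of 3-methoxyphenyl for 4-fluorophenyl on the amine nitrogen in the ring gives no change at the digits printed from compound 1 to compound 4 (within the scatter) and so shows that this place can carry either group at the dose given. For the compounds shown here, the only earlier step on this aromatic ring, a number 75 percentage points higher from compound 2 to compound 3 (beyond the scatter) for hydrogen in place of trifluoromethyl, belongs to a different pair of compounds and showed that a substituent there can matter a great deal; the new step adds that a methoxy group can give way to a fluorine atom, at a different number on the ring, with no difference in this read-out beyond the scatter. No measurement at hand offers an explanation for this result.

The compounds shown leave open whether the same read-out would appear with a chlorine atom, a nitrile or a hydroxyl group on the aromatic ring, or with a plain phenyl ring on the core of compound 1. They also leave open whether compound 1 and compound 4 would still read alike at a lower dose, as this read-out comes from one dose and is not a potency.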